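This account rests on a few compounds, and the source may have more. Where it says the series, first, only, none or still open, it means among the compounds named here.

Of the compounds shown here, three have so far been tested in a functional assay on Raji cells (Homo sapiens) for cytotoxicity, with a stated time of 72 h; on this read-out lower numbers stand for an effect already at smaller amounts and higher numbers for an effect only at larger amounts of compound. Compound 1 (`C=C[C@@](C)(/C=C/c1ccc(OCc2ccccc2)cc1)CCC=C(C)C`) gives > 26000 nM, which is a limit and not a number. Compound 2 (`C=C[C@](C)(CCCC(C)C)CCc1ccc(O)cc1`) gives > 26000 nM, which is also a limit. Compound 3 (`C=C[C@@](C)(/C=C/c1ccc(O)cc1)CCC1OC1(C)C`) gives > 22500 nM, and this too is a limit, so compound 3 has no exact number and no rank among the three.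

Compound 4 (`C=C[C@@](C)(/C=C/c1ccc(O)cc1)CCC=O`) differs from compound 3 in one place: formyl in place of 3,3-dimethyloxiran-2-yl on a saturated chain carbon, three bonds along the chain from two double-bonded chain carbons.

Going by the values given here, no two measured compounds differ in only one place, so no measured step shows how large such a change might be. The expectation is therefore no shift beyond the usual scatter, in either direction, starting from the > 22500 nM of compound 3. The expected step is a step that the limit leaves unreadable from compound 3 to compound 4. For compound 4 the estimate is 25000 nM, with an expected range from 10000 nM to 45000 nM.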

Compound 4, half-maximal effective concentration: > 26000 nM
Compound 4 was reported as a limit; the forecaster's own chance of this, stated with the estimate: 75%; at least 1.0-fold (0.01 log units) between middle value and limit.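

Going by these compounds alone, compound 3 and compound 4 are both reported only as limits, so no step between them can be read. The compounds shown leave open what exact value any of them has in this assay, and whether formyl in place of 3,3-dimethyloxiran-2-yl changes it at all.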